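A few compounds are considered here, and "the series" means these few. Any claim that something is new, unique, unknown or untested is made for them only; others in the source may bear on it.

In a functional assay on MCF7 cells (Homo sapiens) for antiproliferative activity, read by MTT assay, with a stated time of 72 h (a lower number here means a stronger inhibitor, a higher number a weaker inhibitor), compound 1 `CCN(CC)CCCNC(=O)c1ccc(C(CC)(CC)c2ccc(C#CC(O)(CC)CC)c(C)c2)n1CC` gives 17800 nM, compound 2 `CCn1c(C(=O)NCCCO)ccc1C(CC)(CC)c1ccc(C#CC(O)(CC)CC)c(C)c1` gives 5950 nM and compound 3 `CCN(CC)CCNC(=O)c1cc(C(CC)(CC)c2ccc(C#CC(O)(CC)CC)c(C)c2)cn1CC` gives 1800 nM, the lowest of the three numbers. Compound 4 `CCn1cc(C(CC)(CC)c2ccc(C#CC(O)(CC)CC)c(C)c2)cc1C(=O)NCCC(=O)O` differs from compound 3 in one place: carboxy in place of diethylamino on a saturated chain carbon, two bonds along the chain from an amide-type nitrogen. In words, carboxy stands in place of diethylamino on a saturated chain carbon, two bonds along the chain from an amide-type nitrogen.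

Going by the values given here, only one measured step bears on this change. Hydroxy in place of diethylamino gave a 3.0-fold lower number from compound 1 to compound 2 (0.48 log units; beyond the scatter), a modest step beyond the scatter. It is an imperfect guide, since hydroxy is not carboxy, that change lies three bonds along the chain rather than two, and the core of compound 1 differs from that of compound 3. Among the compounds with values here, no measured compound carries a carboxy group, so no step beyond the scatter is expected in this assay, and either direction remains open. The estimated change is a 1.4-fold higher number from compound 3 to compound 4 (0.14 log units; within the scatter). For compound 4 the expected value is 2500 nM, with an estimated range of 600 nM to 12000 nM.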

Compound 4, half-maximal inhibitory concentration: 30600 nM
Compound 4: middle estimate off by 12-fold (1.09 log units), on the low side, outside the stated range (above it).
By their numbers in this assay, from the lowest: compound 3; then compound 2; then compounds 1 and 4 (each within the scatter of the next).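

In this assay, carboxy on this saturated chain carbon, two bonds along the chain from an amide-type nitrogen, gives a 17-fold higher number from compound 3 to compound 4 (1.23 log units; beyond the scatter), a large step. The only earlier replacement of diethylamino, by hydroxy, went the other way with a 3.0-fold lower number from compound 1 to compound 2 (0.48 log units; beyond the scatter), so replacing diethylamino has no single direction across these two pairs, which also differ in the entering group, the place along the chain and the core. Nothing measured here accounts for the size or direction of the new step.

Going by these compounds, whether hydroxy at this place on the core of compound 3 would follow compound 2 or compound 4 remains open. So does whether a methyl ester, a primary amide or a longer chain ending in a carboxylic acid would give a number like that of compound 4.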